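This account rests on a few compounds, and the source may have more. Where it says the series, first, only, none or still open, it means among the compounds named here.

Measured so far:
compound 1, `O=C(CN(c1ncnc2c1ncn2C1CCCCO1)C1CC1)N[C@@H](CCC(=O)OCc1ccccc1)C(=O)OCc1ccccc1`, 34.7%;
compound 2, `O=C(CN(c1ncnc2c1ncn2C1CCCCO1)C1CC1)N[C@@H](CO)C(=O)OCc1ccccc1`, 46.7%;
compound 3, `O=C(CN(c1ncnc2c1ncn2C1CCCCO1)C1CC1)N[C@@H](CC(=O)OCc1ccccc1)C(=O)OCc1ccccc1`, 38.2%.

These values come from a functional assay on the whole organism (Tail, strain ICR) with Mus musculus as the target, in the tail flick test, with a stated time of 60 min, at a dose of 25 umol/kg by the oral route; a higher number here means a stronger effect of the compound at the dose given, a lower number a weaker effect. Compound 3 lies within the usual scatter of both others: the step of a number 3.5 percentage points higher from compound 1 to compound 3 (within the scatter) and the step of a number 8.5 percentage points lower from compound 2 to compound 3 (within the scatter) are both too small to count. For the measured compounds named here, only the step of a number 12 percentage points higher from compound 1 to compound 2 (beyond the scatter) is modest and beyond the scatter. Compound 4, `N=C(N)NCCC[C@H](NC(=O)CN(c1ncnc2c1ncn2C1CCCCO1)C1CC1)C(=O)OCc1ccccc1`, has not been measured yet. It differs from compound 3 in one place: a group of 6 heavy atoms (3 carbon, 3 nitrogen; no ring) in place of a group of 10 heavy atoms (8 carbon, 2 oxygen; one six-membered aromatic ring of carbon only), on a saturated chain carbon, two bonds along the chain from an amide-type nitrogen and a carbonyl carbon. The two steps into compound 3 bear on this, since they swap groups on the same saturated chain carbon, and neither exceeded the scatter. Compound 4 is therefore expected to stay near compound 3, with a step of a number 3.8 percentage points higher from compound 3 to compound 4 (within the scatter) and an estimated value of 42%, between 25% and 60%.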

Compound 4, a percentage reported as activity, at one dose (the size of the read-out at that dose, not a potency): 52.4%
Compound 4: middle estimate off by 10.4 percentage points, on the low side; low and high end bracket the measured number.
By their numbers in this assay, from the lowest: compounds 1, 3, 2 and 4 (each within the scatter of the next, the first and the last beyond it).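

For the compounds shown here, at this saturated chain carbon, the group of 6 heavy atoms with no ring is the first replacement of benzyloxycarbonyl in this assay to give a step beyond the scatter (a number 14.2 percentage points higher from compound 3 to compound 4 (beyond the scatter)). The ringless group also stands clear of the longer (benzyloxycarbonyl)methyl compound (a number 17.7 percentage points higher from compound 1 to compound 4 (beyond the scatter)) but not of the hydroxy compound (a number 5.7 percentage points higher from compound 2 to compound 4 (within the scatter)), so an aromatic ring is not needed here for this level of effect. Nothing available explains these steps.

On these data alone, whether a plain amine at the chain end would match this group remains open. So does what a longer chain would do.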